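Benzyl for 4-chlorophenyl on a triazole nitrogen, across two cores

A few compounds are considered here, and "the series" means these few. Any claim that something is new, unique, unknown or untested is made for them only; others in the source may bear on it.

Compound 1 `CCCCCc1ccc(C#Cc2c(-c3ccc(CCCCC)cc3)oc3nc(=O)n(Cc4cn(-c5ccc(Cl)cc5)nn4)cc23)cc1`: in a functional assay on HepG2 cells (Homo sapiens) for antiproliferative activity, read by MTT assay, with a stated time of 72 h (on this read-out higher numbers stand for weaker inhibition and lower numbers for stronger inhibition), compound 1 gives > 100000 nM, which is a limit of the assay and not a number.
Compound 2 `CCCCCc1ccc(C#Cc2c(-c3ccc(CCCCC)cc3)oc3nc(=O)n(Cc4cn(Cc5ccccc5)nn4)cc23)cc1`: in this assay compound 2 gives > 100000 nM, again only a limit.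
Compound 3 `O=c1nc2oc(C3CC3)cc2cn1Cc1cn(-c2ccc(Cl)cc2)nn1`: in this assay compound 3 gives > 100000 nM, once more a limit.

Compound 1 and compound 2 share one core and differ in a single place, (benzyl in place of 4-chlorophenyl on an aromatic nitrogen). Because both values are limits, the step that the two limits leave unreadable from compound 1 to compound 2 cannot be read: it may be small or large, and nothing in the numbers tells which. Compound 3 carries a different core; the difference between the two cores is not broken down here, so compound 3 is compared with compound 1 only through their two values, and both are limits.

Compound 4 `O=c1nc2oc(C3CC3)cc2cn1Cc1cn(Cc2ccccc2)nn1` is not yet measured. It differs from compound 3 by benzyl in place of 4-chlorophenyl on an aromatic nitrogen, the same change that separates compound 1 from compound 2, made at the same place on the ring. Among the measured compounds shown here, every value known so far sits at the limit of > 100000 nM in this assay, at which 3 of the 3 values shown sit, and the one earlier instance of this change, a step that the two limits leave unreadable from compound 1 to compound 2, left that limit untouched. On that basis compound 4 is expected to show a step of about a number no higher from compound 3 to compound 4 (the limit leaves the size open). Compound 4 is therefore estimated at around 100000 nM, most likely reported again as a limit. The expected range for compound 4 runs from 30000 nM to 300000 nM.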

Compound 4, half-maximal inhibitory concentration: 49100 nM
Estimate against measurement, compound 4: 2.0-fold (0.31 log units) above; the range from low to high includes it.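

Putting benzyl in place of 4-chlorophenyl on an aromatic nitrogen gives, in this assay, an at least 2.0-fold lower number from compound 3 to compound 4 (0.30 log units; that floor lies within the scatter), so on the core of compound 3 the change has a direction that can be read, although the smallest size it could have does not go beyond the usual scatter of repeated measurements. On the core of compound 1 the same change cannot be read, as compound 1 and compound 2 both sit at a limit of the assay, so the data cannot say whether the change behaves alike on the two cores or differently. Compound 4 alone carries a real number here, and a single readable step on a single core makes no rule for the series: the limit of > 100000 nM in this assay, at which 3 of the 4 values shown sit.

Going by these compounds, the true distance between compound 3 and compound 4 remains open, as the value for compound 3 is a limit and the step could be much larger than its floor. Among the compounds shown, only benzyl and 4-chlorophenyl stand on this nitrogen, so what a group such as an amine, a carboxylic acid or a longer alkyl chain would do at this place is unknown.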